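Aryl exchange at the amine-bound chain carbon: compound 4

A few compounds are considered here, and "the series" means these few. Any claim that something is new, unique, unknown or untested is made for them only; others in the source may bear on it.

Values in an assay on isolated protein for activation of cGMP-dependent protein kinase 1 (Homo sapiens), read by ADP-Glo, with stated times of 120 min and 40 min; on this read-out higher numbers stand for an effect only at larger amounts of compound and lower numbers for an effect already at smaller amounts:
compound 1, `Clc1cc(Cl)cc(CO[C@H]2CCCN(Cc3ccccn3)[C@H]2c2ccccc2)c1`, gives > 200000 nM, a limit of the assay.
compound 2, `Clc1cc(Cl)cc(CO[C@H]2CCCN(Cc3ncco3)[C@H]2c2ccccc2)c1`, gives > 200000 nM, a limit of the assay.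
compound 3, `O=C(O)c1ccc(CN2CCC[C@H](OCc3cc(Cl)cc(Cl)c3)[C@@H]2c2ccccc2)cn1`, gives > 200000 nM, a limit of the assay.

Compound 3 thus stands at the limit, together with the other two (the limit of > 200000 nM in this assay, at which 3 of the 3 values shown sit). The steps a step that the two limits leave unreadable from compound 1 to compound 2, a step that the two limits leave unreadable from compound 1 to compound 3 and a step that the two limits leave unreadable from compound 2 to compound 3 are all unreadable. Compound 4, `O=C(O)c1ccc(CN2CCC[C@H](OCc3cc(Cl)cc(Cl)c3)[C@@H]2c2ccccc2)cc1`, differs from compound 3 by 4-carboxyphenyl in place of 6-carboxypyridin-3-yl on a saturated chain carbon bound to an amine nitrogen in a ring. The steps into compound 3 concern the same place, yet give no size or direction. All three variations at this place sit at the limit (the limit of > 200000 nM in this assay, at which 3 of the 3 values shown sit); compound 4 is expected to remain there as well. Compound 4 is estimated at 300000 nM, with a range of 100000 nM to 2000000 nM. The step that the limit leaves unreadable from compound 3 to compound 4 is the expected outcome.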

Compound 4, half-maximal effective concentration: 76000 nM
Beside the measured number, compound 4's estimate is 3.9-fold (0.60 log units) above it; the measured number lies below the stated range.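

This position responds to the aryl group: 4-carboxyphenyl in place of 6-carboxypyridin-3-yl gives an at least 2.6-fold lower number from compound 3 to compound 4 (0.42 log units; beyond the scatter), and the same group gives an at least 2.6-fold lower number from compound 2 to compound 4 (0.42 log units; beyond the scatter) and an at least 2.6-fold lower number from compound 1 to compound 4 (0.42 log units; beyond the scatter). The steps among compounds 1, 2 and 3 cannot be read. Compound 3 also carries a carboxy group yet stays at a limit of the assay, so a carboxy group alone does not bring a compound off it: the limit of > 200000 nM in this assay, at which 3 of the 4 values shown sit.

Going by these compounds, the full size of the three steps stays open. Also open, on these data alone, is whether a carboxylic acid on a longer chain, or a primary amide in its place, would serve on the phenyl ring.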